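This account rests on a few compounds, and the source may have more. Where it says the series, first, only, none or still open, it means among the compounds named here.

Measured compounds:
compound 1 `Cc1ccc(-c2cc(NC(=O)c3cncc(Br)c3)n[nH]2)cc1`, in a functional assay on A-375 cells (Homo sapiens) for antiproliferative activity, read by MTT assay, with a stated time of 48 h (a higher number here means a weaker inhibitor, a lower number a stronger inhibitor), compound 1 gives 7050 nM;
compound 2 `Cc1ccc(-c2cc(NC(=O)c3ccc(Br)nc3)n[nH]2)cc1`, compound 2 gives 7670 nM;
compound 3 `O=C(Nc1cc(-c2ccc(Br)cc2)[nH]n1)c1cncc(Br)c1`, compound 3 gives 9420 nM.

Compound 4 `O=C(Nc1cc(-c2ccc(Br)cc2)[nH]n1)c1ccc(Br)nc1` has not yet been measured. It differs from compound 3 by 6-bromopyridin-3-yl in place of 5-bromopyridin-3-yl on a carbonyl carbon, and the same change is already measured from compound 1 to compound 2, where it differs as 6-bromopyridin-3-yl in place of 5-bromopyridin-3-yl on a carbonyl carbon; that change gave a 1.1-fold higher number from compound 1 to compound 2 (0.04 log units; within the scatter). The two cores differ by bromo in place of methyl on an aromatic carbon, a difference that gave a 1.3-fold higher number from compound 1 to compound 3 (0.13 log units; within the scatter). Since the two "place" descriptions read the same, the account treats the change as the same change. The step from compound 3 to compound 4 is expected to be a 1.1-fold higher number from compound 3 to compound 4 (0.03 log units; within the scatter), a step resting on the earlier one, because a 1.1-fold higher number from compound 1 to compound 2 (0.04 log units; within the scatter) lay within the scatter. For compound 4 the estimate is 10000 nM, between 5000 nM and 20000 nM.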

Compound 4, half-maximal inhibitory concentration: 9910 nM
Compound 4: middle estimate off by 1.0-fold (0.00 log units), on the high side, within the range that was stated.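

In this assay, 6-bromopyridin-3-yl in place of 5-bromopyridin-3-yl on a carbonyl carbon gives a 1.1-fold higher number from compound 3 to compound 4 (0.02 log units; within the scatter), matching what the same change gave on the core of compound 1: the same change on two cores in this assay, a 1.1-fold higher number (0.04 log units; within the scatter) from compound 1 to compound 2 and a 1.1-fold higher number (0.02 log units; within the scatter) from compound 3 to compound 4, 1.0-fold (0.01 log units) apart, within the scatter of two such steps.
Bromo in place of methyl on an aromatic carbon gives a 1.3-fold higher number from compound 2 to compound 4 (0.11 log units; within the scatter), and this change also carries over: the same change on two cores in this assay, a 1.3-fold higher number (0.13 log units; within the scatter) from compound 1 to compound 3 and a 1.3-fold higher number (0.11 log units; within the scatter) from compound 2 to compound 4, 1.0-fold (0.01 log units) apart, within the scatter of two such steps.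
Both changes thus transfer between these two cores, but only as steps within the scatter, so this does not show that either change affects the number, or that a change with a larger effect would transfer in the same way.

The compounds shown leave open whether an aminopyridinyl or carboxyphenyl group on the carbonyl carbon would give a step beyond the scatter. The same question stands for methoxy or an amine in place of bromo on an aromatic carbon.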